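Cytotoxicity across the aryl substituent: expectation for compound 4

The compounds below may be only part of what the source reports. "The series", "measured", "known", "first", "only" and "open" are said of these compounds alone.

Compound 3 `COc1cccc(CNCCCNc2ccnc3cc(Oc4ccc(F)cc4)ccc23)c1O` stands highest of the three measured numbers in an ADME assay on HepG2 cells (Homo sapiens) for cytotoxicity, read by luminescence, CellTiter-Glo and ATP content, with a stated time of 72 h (on this read-out lower numbers stand for an effect already at smaller amounts and higher numbers for an effect only at larger amounts of compound), giving 11000 nM. Compound 1 `COc1cccc(CNCCCNc2ccnc3cc(C4CCCCC4)ccc23)c1O` gives 1080 nM and compound 2 `COc1cccc(CNCCCNc2ccnc3cc(Cc4cc(C)cc(C)c4)ccc23)c1O` gives 2680 nM. The change to compound 4 `COc1cccc(CNCCCNc2ccnc3cc(-c4ccc(C(F)(F)F)cc4)ccc23)c1O` is 4-(trifluoromethyl)phenyl in place of 4-fluorophenoxy on an aromatic carbon. Among the compounds with values here, the steps that bear on it are those into the phenoxy from a directly attached group: a 10-fold higher number from compound 1 to compound 3 (1.01 log units; beyond the scatter) and a 4.1-fold higher number from compound 2 to compound 3 (0.61 log units; beyond the scatter); between the two directly attached groups the step was a 2.5-fold higher number from compound 1 to compound 2 (0.39 log units; beyond the scatter). Both steps into the phenoxy raised the number, so returning to a directly attached aryl in compound 4 is expected to lower it by a modest step, a 3.7-fold lower number from compound 3 to compound 4 (0.56 log units; beyond the scatter). The estimate for compound 4 is 3000 nM, expected to lie between 1000 nM and 10000 nM.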

Compound 4, half-maximal effective concentration: 2210 nM
Compound 4: the middle estimate sits 1.4-fold (0.13 log units) above what was measured; the measured number falls inside the stated range.
By their numbers in this assay, from the lowest: compound 1; then compounds 4 and 2 (each within the scatter of the next); then compound 3.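

With 4-(trifluoromethyl)phenyl on this aromatic carbon, this assay gives a 5.0-fold lower number from compound 3 to compound 4 (0.70 log units; beyond the scatter), leaving compound 3 alone at the high end of the four. The same group cannot be told apart from 3,5-dimethylbenzyl, a 1.2-fold lower number from compound 2 to compound 4 (0.08 log units; within the scatter), yet remains separate from cyclohexyl, a 2.0-fold higher number from compound 1 to compound 4 (0.31 log units; beyond the scatter). No measurement available here accounts for these steps.

The step from compound 3 to compound 4 changes the oxygen link and the ring substituent together, and the two are not separated. Going by these compounds, how an unsubstituted phenyl or a carboxylic acid would read at this position stays open.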